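The compounds below may be only part of what the source reports. "The series", "measured", "known", "first", "only" and "open" are said of these compounds alone.

Measured so far in a functional assay, read by spectrophotometry, with a stated time of 5 min; on this read-out lower numbers stand for stronger inhibition and higher numbers for weaker inhibition:
- compound 1, `CCOc1ccc(C=C(C(=O)/C=C/c2ccc(O)c(OC)c2)C(=O)/C=C/c2ccc(O)c(OC)c2)cc1OCC`, gives 10000 nM
- compound 2, `COc1cc(/C=C/C(=O)C(=Cc2ccccc2)C(=O)/C=C/c2ccc(O)c(OC)c2)ccc1O`, gives 8580 nM
- compound 3, `CCOc1cc(/C=C/C(=O)C(=Cc2ccc(OCC)c(OCC)c2)C(=O)/C=C/c2ccc(O)c(OCC)c2)ccc1O`, gives 20200 nM

Compound 3 has the highest of the three numbers, and its gap to both others is beyond the usual scatter. Between compound 1 and compound 2 the change is phenyl in place of 3,4-diethoxyphenyl on a double-bonded chain carbon bound to a double-bonded chain carbon, and that step came out as a 1.2-fold lower number from compound 1 to compound 2 (0.07 log units; within the scatter).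

Compound 4, `CCOc1cc(/C=C/C(=O)C(=Cc2ccccc2)C(=O)/C=C/c2ccc(O)c(OCC)c2)ccc1O`, is not yet measured in this assay. It is made from compound 3 by the change (phenyl in place of 3,4-diethoxyphenyl on a double-bonded chain carbon bound to a double-bonded chain carbon), the same change as from compound 1 to compound 2, at a place described in exactly the same words. How the core of compound 3 differs from the core of compound 1 is not broken down here.

Because the earlier step was a 1.2-fold lower number from compound 1 to compound 2 (0.07 log units; within the scatter), a step of about the same small size is expected here, a 1.2-fold lower number from compound 3 to compound 4 (0.07 log units; within the scatter), which stays within the scatter. On that basis compound 4 is estimated to give about 17000 nM in this assay, likely somewhere between 8000 nM and 35000 nM.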

Compound 4, half-maximal inhibitory concentration: 20400 nM
Compound 4: the middle estimate sits 1.2-fold (0.08 log units) below what was measured; the range from low to high includes it.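

In this assay, putting phenyl in place of 3,4-diethoxyphenyl on a double-bonded chain carbon bound to a double-bonded chain carbon gives a 1.0-fold higher number from compound 3 to compound 4 (0.00 log units; within the scatter), a step too small to tell apart from repeat measurement. Set beside the earlier step, the change reads the same on both cores: the same change on two cores in this assay, a 1.2-fold lower number (0.07 log units; within the scatter) from compound 1 to compound 2 and a 1.0-fold higher number (0.00 log units; within the scatter) from compound 3 to compound 4, 1.2-fold (0.07 log units) apart, within the scatter of two such steps. This shows that, on these two cores, the larger group can be swapped for plain phenyl with no measurable penalty or gain, but since neither step is beyond the scatter, it does not show that a real effect of this change carries over from one core to another, and two cores say nothing about a third.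

The compounds shown hold only phenyl and 3,4-diethoxyphenyl at this place, so it stays open whether a different group there, such as an amine or a carboxylic acid on the ring, would move the number at all. If such a group did, it would also remain to be seen whether that step held on both cores.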